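A few compounds are considered here, and "the series" means these few. Any claim that something is new, unique, unknown or untested is made for them only; others in the source may bear on it.

The measured compounds and their numbers in a physicochemical assay on A549 cells for solubility, read by microscopy, with a stated time of 24 h; on this read-out lower numbers stand for stronger inhibition and higher numbers for weaker inhibition:
Compound 1 `O=C(N/N=C/c1ccccc1O)c1cc(-c2ccc(Cl)cc2)nn1Cc1ccc(Cl)nc1` gives 500 nM.
Compound 2 `O=C(N/N=C/c1ccccc1O)c1cc(-c2ccc(Cl)cc2)nn1Cc1ccccc1` gives 680 nM.
Compound 3 `CC(C)(C)c1ccc(Cn2nc(-c3ccc(Cl)cc3)cc2C(=O)N/N=C/c2ccccc2O)cc1` gives 430 nM.

All three compounds share the same core and differ only in the group on the saturated chain carbon bound to the aromatic nitrogen. The three numbers lie within the usual scatter of one another: a 1.4-fold higher number from compound 1 to compound 2 (0.13 log units; within the scatter), a 1.2-fold lower number from compound 1 to compound 3 (0.07 log units; within the scatter) and a 1.6-fold lower number from compound 2 to compound 3 (0.20 log units; within the scatter). Compound 3 therefore stands among the others without a separation that the measurements can resolve.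

Compound 4 `COc1ccc(-c2cc(C(=O)N/N=C/c3ccccc3O)n(Cc3ccc(C(C)(C)C)cc3)n2)cc1` is the unmeasured compound. It differs from compound 3 by methoxy in place of chloro on an aromatic carbon. Within the data shown here, none of the measured steps touches this ring; all three concern the benzylic group on the other side of the core, and all three stayed within the scatter. Among the measured compounds shown here, there is thus no measured step that bears directly on the change from compound 3 to compound 4, and the only guidance is that the series so far has been flat. On that basis a step of no size beyond the scatter is expected, in either direction, so that a 1.0-fold higher number from compound 3 to compound 4 (0.02 log units; within the scatter) is the estimated outcome. In this assay compound 4 is expected to give about 450 nM, with a plausible range from 200 nM to 1000 nM.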

Compound 4, half-maximal inhibitory concentration: 550 nM
Estimate against measurement, compound 4: 1.2-fold (0.09 log units) below, and the stated range covers the measured number.
By their numbers in this assay, from the lowest: compounds 3, 1, 4 and 2 (each within the scatter of the next).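

In this assay, methoxy in place of chloro, on an aromatic carbon of a six-membered aromatic ring of carbon only and para to a large group, gives a 1.3-fold higher number from compound 3 to compound 4 (0.11 log units; within the scatter). This is the only step shown at this ring, since the earlier compounds all carried 4-chlorophenyl and varied only the group on the saturated chain carbon bound to the aromatic nitrogen, so it extends the flat picture to a second place on the shared core: every step among the four compounds lies within the scatter, and none goes against this. Nothing shown accounts for why the exchange of chloro for methoxy, which brings in a hydrogen-bond acceptor, leaves the number within the scatter.

The compounds shown carry only chloro and methoxy at this place, both read alongside the 4-(tert-butyl)phenyl group, so it stays open whether the same exchange would read alike with phenyl or 6-chloropyridin-3-yl on the chain carbon. As far as these compounds go, it also stays open whether an amine, a carboxylic acid or a longer alkoxy chain at this place would move the number beyond the scatter.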